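The compounds below may be only part of what the source reports. "The series", "measured", "known", "first", "only" and "open" are said of these compounds alone.

Working notes on the series. For the measured compounds named here, in a functional assay on MCF7 cells (Homo sapiens) for antiproliferative activity, read by CellTiter-Glo, with a stated time of 5 days (on this read-out lower numbers stand for stronger inhibition and higher numbers for weaker inhibition), compound 1 `CC1=C(c2cccc(O)c2)[C@H](c2ccc(OC[C@H](C)N3CC[C@@H](C)C3)cc2)Oc2ccc(O)cc21` gives 0.1 nM, the lower of the two numbers so far, while compound 2 `CC1=C(c2ccc(S(C)(=O)=O)cc2)C(c2ccc(OC[C@H](C)N3CC[C@@H](C)C3)cc2)Oc2ccc(O)cc21` gives 27 nM, a gap beyond the scatter. Compound 3 `CC1=C(c2cccc(O)c2)C(c2ccc(OC[C@@H](C)N3CC[C@@H](C)C3)cc2)Oc2ccc(O)cc21` stays close to compound 1 in structure: the two compounds have the same atoms and bonds; at least one stereo element is drawn with a configuration in one of them and without one in the other: 2 of 3 stereo elements differ; a stereocentre at a saturated ring carbon is drawn S in compound 1 and without a configuration in compound 3; a stereocentre at a saturated chain carbon is drawn S in compound 1 and R in compound 3. The stereocentre at the saturated chain carbon is therefore inverted, and the one at the saturated ring carbon is left without a drawn configuration.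

Going by the values given here, no measured pair shows the size of such a change, so the expectation rests on position alone. Compound 1 stands at the low end with 0.1 nM, which leaves a move to a higher number in this assay as the likelier direction. A moderate weakening, beyond the scatter, is expected, and the estimated step is a 10-fold higher number from compound 1 to compound 3 (1.00 log units; beyond the scatter). For compound 3 the estimated value is 1 nM, with an expected range of 0.2 nM to 8 nM.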

Compound 3, half-maximal inhibitory concentration: 0.2 nM
Estimate against measurement, compound 3: 5.0-fold (0.70 log units) above; low and high end bracket the measured number.
By their numbers in this assay, from the lowest: compounds 1 and 3 (each within the scatter of the next); then compound 2.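

The step is a 2.0-fold higher number from compound 1 to compound 3 (0.30 log units; within the scatter) in this assay. For the compounds shown here, this is the first pair with the same atoms and bonds, and inverting the saturated chain carbon from S to R, with the saturated ring carbon left undrawn, does not separate the two compounds on this read-out. The step cannot be assigned to the chain carbon alone, because the two stereo differences arrive together, and the pair carries this limit: the fact that one of compounds 1 and 3 is drawn with a defined configuration and the other without, at the place where they differ

Still open is how each configuration at the saturated ring carbon reads when the chain carbon is held fixed, since the compounds shown do not vary the two stereocentres one at a time. Also open, going by these compounds, is how a longer chain, such as an ethyl group in place of the methyl on the saturated chain carbon, would read in this assay.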